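Aryl swap on the shared core: methoxy position moved

The source may report more compounds than this note shows. Statements on the series, on what has been measured and on what is new or still open speak of the compounds shown alone.

Compound 1 `COc1ccc(-c2cc(COC(Cc3cn(C4CCN(Cc5ccc([N+](=O)[O-])cc5)CC4)nn3)c3ccc(Br)cc3)on2)cc1` gives 4000 nM in a functional assay on MCF7 cells (Homo sapiens) for cytotoxicity, with a stated time of 48 h; on this read-out lower numbers stand for stronger inhibition and higher numbers for weaker inhibition. For the measured compounds named here, its only measured neighbour, compound 2 `O=[N+]([O-])c1ccc(CN2CCC(n3cc(CC(OCc4cc(-c5cccc(Br)c5)no4)c4ccc(Br)cc4)nn3)CC2)cc1`, gives 6000 nM in this assay; the two numbers cannot be told apart, since a 1.5-fold higher number from compound 1 to compound 2 (0.18 log units; within the scatter). Compound 3 `COc1ccccc1-c1cc(COC(Cc2cn(C3CCN(Cc4ccc([N+](=O)[O-])cc4)CC3)nn2)c2ccc(Br)cc2)on1` has not been measured. It differs from compound 1 by 2-methoxyphenyl in place of 4-methoxyphenyl on an aromatic carbon. Going by the values given here, the one step that bears on this change is the aryl swap at the same ring carbon, a 1.5-fold higher number from compound 1 to compound 2 (0.18 log units; within the scatter), which replaced the whole group and still stayed inside the scatter. Moving the methoxy group within the same ring is a smaller change than that exchange, so no step beyond the scatter is expected in this assay, in either direction. Compound 3 is therefore expected to give about 4500 nM, with a range of 2000 nM to 12000 nM, which means an expected step of a 1.1-fold higher number from compound 1 to compound 3 (0.05 log units; within the scatter).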

Compound 3, half-maximal inhibitory concentration: 3000 nM
Estimate against measurement, compound 3: 1.5-fold (0.18 log units) above; the measured number falls inside the stated range.
By their numbers in this assay, from the lowest: compounds 3, 1 and 2 (each within the scatter of the next).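

Placing the methoxy group as 2-methoxyphenyl instead of 4-methoxyphenyl on the aromatic carbon next to the ring nitrogen gives no separable change in this assay (a 1.3-fold lower number from compound 1 to compound 3 (0.12 log units; within the scatter)). The comparison with the 3-bromophenyl group also stays within the scatter (a 2.0-fold lower number from compound 2 to compound 3 (0.30 log units; within the scatter)), so 2-methoxyphenyl, 4-methoxyphenyl and 3-bromophenyl cannot be told apart at this position on this read-out. No measurement on hand bears on why these three groups read alike.

From the compounds shown here alone, all three compounds carry a substituted phenyl ring at this carbon, so it remains open whether any group there can produce a step beyond the scatter. A phenyl ring bearing an amine or a carboxylic acid, or a longer alkyl chain in place of the ring, would test this.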